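The source may report more compounds than this note shows. Statements on the series, on what has been measured and on what is new or still open speak of the compounds shown alone.

Compound 1 `O=c1cc(/C=C/c2ccc(Cl)cc2)[nH]cc1O` gives 11500 nM

Compound 2 `CN(C)c1ccc(/C=C/c2cc(=O)c(O)c[nH]2)cc1` gives 3410 nM

Compound 3 `CCOc1ccc(/C=C/c2cc(=O)c(O)c[nH]2)cc1` gives 8120 nM

All three numbers come from a functional assay, with a stated time of 10 min (a lower number here means a stronger inhibitor, a higher number a weaker inhibitor), and span a narrow range. Compound 3 stands level with compound 1, as a 1.4-fold lower number from compound 1 to compound 3 (0.15 log units; within the scatter) shows, but apart from compound 2, as a 2.4-fold higher number from compound 2 to compound 3 (0.38 log units; beyond the scatter) shows.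

Compound 4 `O=c1cc(/C=C/c2ccc(O)cc2)[nH]cc1O` changes compound 3 in one place: hydrogen in place of ethyl on an oxygen on an aromatic ring. Put simply, ethoxy becomes hydroxy, with hydrogen in place of ethyl on an oxygen on an aromatic ring.

Among the compounds with values here, no measured compound carries a hydroxy group, so no step shows this exact change. The nearest guides are the swaps of the whole group on an aromatic carbon. The largest is a 3.4-fold lower number from compound 1 to compound 2 (0.53 log units; beyond the scatter), and it is only modest. The other two are a 1.4-fold lower number from compound 1 to compound 3 (0.15 log units; within the scatter) and a 2.4-fold higher number from compound 2 to compound 3 (0.38 log units; beyond the scatter). With steps of this size as the guide, a small change is expected in this assay, probably within the scatter, and the data give no firm direction.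

The estimate means an expected 1.4-fold lower number from compound 3 to compound 4 (0.13 log units; within the scatter).

For compound 4 the expected value is 6000 nM, with an estimated range from 2000 nM to 18000 nM.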

Compound 4, half-maximal inhibitory concentration: 1730 nM
Compound 4: middle estimate off by 3.5-fold (0.54 log units), on the high side; measured number outside the range, below it.
By their numbers in this assay, from the lowest: compounds 4 and 2 (each within the scatter of the next); then compounds 3 and 1 (each within the scatter of the next).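

In this assay, a small edit at this position has a clear effect: hydrogen in place of ethyl on the oxygen gives a 4.7-fold lower number from compound 3 to compound 4 (0.67 log units; beyond the scatter), so removing just the ethyl moves the number past the scatter. Hydroxy also stands apart from chloro, with a 6.6-fold lower number from compound 1 to compound 4 (0.82 log units; beyond the scatter), but it cannot be told apart from dimethylamino, with a 2.0-fold lower number from compound 2 to compound 4 (0.29 log units; within the scatter), so the four compounds now fall into two groups, with compounds 2 and 4 on the stronger side and compounds 1 and 3 on the weaker side. Nothing in the data explains why hydroxy and dimethylamino sit together, or why ethoxy and chloro do.

The compounds shown leave open whether any other group on this aromatic carbon, such as a primary amine or a carboxylic acid, could go clearly beyond hydroxy and dimethylamino. A methoxy group would help show whether shortening the chain on the oxygen is enough for a step of this size, or whether the oxygen has to carry a hydrogen.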